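From compound 2 to compound 3: swapping aminomethyl for piperidin-4-yl

This account rests on a few compounds, and the source may have more. Where it says the series, first, only, none or still open, it means among the compounds named here.

Compound 1 (`O=C(NCCC1CCNCC1)Nc1nc2ccc(C(=O)c3ccccc3)cc2[nH]1`) gives > 30000 nM as a limit
Compound 2 (`NCCCC(=O)Nc1nc2ccc(C(=O)c3ccccc3)cc2[nH]1`) gives > 30000 nM as a limit

Both results come from an ADME assay on HL-60 cells (Homo sapiens) for cytotoxicity, read by resazurin assay, with a stated time of 72 h (on this read-out lower numbers stand for an effect already at smaller amounts and higher numbers for an effect only at larger amounts of compound), and neither is an exact number. The evidence so far is the limit of > 30000 nM in this assay, at which 2 of the 2 values shown sit, and nothing more. Compound 2 stands at > 30000 nM and that is a limit.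

Compound 3 (`O=C(CCC1CCNCC1)Nc1nc2ccc(C(=O)c3ccccc3)cc2[nH]1`) has piperidin-4-yl in place of aminomethyl on a saturated chain carbon, two bonds along the chain from a carbonyl carbon. The same difference can be read as 3-aminopropyl to 2-(piperidin-4-yl)ethyl.

Among the measured compounds shown here, the one measured step that bears on this is a step that the two limits leave unreadable from compound 1 to compound 2 and it puts 3-aminopropyl in place of (2-(piperidin-4-yl)ethyl)amino on a carbonyl carbon. Its size cannot be read, so it offers no direction. For the measured compounds named here, no shift beyond the usual scatter is therefore expected, since compound 2 rests at > 30000 nM and no measured step points either way. In this assay the expected change is a number no higher from compound 2 to compound 3 (the limit leaves the size open) in size, with no direction favoured. For compound 3 the estimate is 30000 nM within a range from 15000 nM to 60000 nM and a reading that is only a limit is the likeliest outcome.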

Compound 3, half-maximal effective concentration: > 30000 nM
Compound 3 gave a limit, no number (the forecaster's own chance of this, stated with the estimate: 80%); the middle value sits exactly at the limit.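

In this assay the steps among compound 1, compound 2 and compound 3 cannot be read, as each result is only a limit: the limit of > 30000 nM in this assay, at which 3 of the 3 values shown sit.

The compounds shown leave open what amount of each would produce a half-maximal effect on these cells, and whether the differences in their side chains change that amount at all.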